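Epimer of compound 1 in mouse microsomal stability

The source may hold more compounds than are shown below. What is called first, only, known or untested is meant among the compounds shown, and "the series" means these compounds.

Compound 1 `c1ccc2c(c1)CN[C@@H](CN(CC[C@H]1CCCNC1)[C@H]1CCCc3cccnc31)C2` sets the reference point: in an ADME assay on microsomes from liver (Mus musculus) for metabolic stability, read by LC-MS, with a stated time of 10 min, tested at 0.5 uM (on this read-out higher numbers stand for a more stable compound and lower numbers for a less stable compound), compound 1 gives 56%. Compound 2 `c1cnc(CN(CCCN2CCNCC2)[C@H]2CCCc3cccnc32)nc1` shares the core of compound 1 but is otherwise built differently; in this assay compound 2 gives 78%. Of the two numbers in hand, compound 1 stands lowest; the value of compound 2 lies higher by a margin beyond the scatter, but no step between these two is tallied here, so the pair is simply shown side by side.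

Compound 3 `c1ccc2c(c1)CN[C@@H](CN(CC[C@@H]1CCCNC1)[C@H]1CCCc3cccnc31)C2` is the untested partner of compound 1: the two compounds have the same atoms and bonds and differ only in configuration as drawn: 1 of 3 stereo elements differ; a stereocentre at a saturated ring carbon is drawn R in compound 1 and S in compound 3. Going by the values given here, no change of configuration at a saturated ring carbon has been followed anywhere, so no measured step points a direction. The expected step is a number 1 percentage points higher from compound 1 to compound 3 (within the scatter), none beyond the scatter. Compound 3 is accordingly estimated to give 57% in this assay, with a range from 42% to 72%.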

Compound 3, percent of the compound remaining: 23%
Beside the measured number, compound 3's estimate is 34 percentage points above it, and the stated range ends above it.
By their numbers in this assay, from the lowest: compound 3; then compound 1; then compound 2.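

Configuration at this saturated ring carbon matters in this assay: going from R to S gives a number 33 percentage points lower from compound 1 to compound 3 (beyond the scatter), the first step in the series that can be read at all. With atoms and bonds unchanged, the read-out in this pair responds to stereochemistry at this one position and not only to the groups present. The step can be assigned to that single stereocentre because nothing else separates the pair: the fact that compounds 1 and 3 differ only in the configuration as drawn.

Which feature of the S form lowers the number stays open, as does the contribution of the remaining stereo elements. Also open, going by these compounds, is whether a methyl group or a fluorine on this saturated ring carbon would leave the read-out nearer that of compound 1 or that of compound 3.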